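Swapping chloro for methyl on a weak amide analogue

This account rests on a few compounds, and the source may have more. Where it says the series, first, only, none or still open, it means among the compounds named here.

In a functional assay on HeLa cells (Homo sapiens) for antiproliferative activity, read by MTT assay, with a stated time of 48 h (on this read-out lower numbers stand for stronger inhibition and higher numbers for weaker inhibition), compound 1 `COc1ccc(C(=O)CSc2nnc(-c3cc(OC)c(OC)c(OC)c3)n2N)cc1` gives 17400 nM, and compound 2 `COc1cccc(NC(=O)CSc2nnc(-c3cc(OC)c(OC)c(OC)c3)n2N)c1` gives 4020 nM. Compound 3 `COc1cc(-c2nnc(SCC(=O)NCc3ccc(Cl)cc3)n2N)cc(OC)c1OC` gives > 100000 nM, which is a limit of the assay rather than a number. Both measured steps into compound 3 raised the number: an at least 5.7-fold higher number from compound 1 to compound 3 (0.75 log units; beyond the scatter) and an at least 24-fold higher number from compound 2 to compound 3 (1.39 log units; beyond the scatter). Compound 4 `COc1cc(-c2nnc(SCC(=O)NCc3ccc(C)cc3)n2N)cc(OC)c1OC` differs from compound 3 in one place: methyl in place of chloro on an aromatic carbon. Among the measured compounds shown here, no measured step touches this group, so the two steps above show only that compound 3 sits at the weak end. The step of a number no higher from compound 3 to compound 4 (the limit leaves the size open) is therefore expected to stay within the usual scatter. Compound 4 is estimated at 100000 nM, between 30000 nM and 300000 nM, with a fair chance that this assay again reports only a limit.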

Compound 4, half-maximal inhibitory concentration: > 100000 nM
Compound 4 was reported as a limit; the forecaster's own chance of this, stated with the estimate: 65%; the middle value sits exactly at the limit.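

Compound 4 also ends at a limit, so the step from compound 3 cannot be read and chloro and methyl cannot be ranked at this position. The weak result is therefore not confined to chloro, for the methyl analogue shows an at least 24-fold higher number from compound 2 to compound 4 (1.39 log units; beyond the scatter) and an at least 5.7-fold higher number from compound 1 to compound 4 (0.75 log units; beyond the scatter). Both benzyl amides stop at one ceiling: the limit of > 100000 nM in this assay, at which 2 of the 4 values shown sit.

As far as these compounds go, an amine or a carboxylic acid in place of the methyl, or a phenethyl group in place of the 4-methylbenzyl, remains open. So does whether any such change would give a readable number.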